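Aromatic substituent series: estimate for compound 4

The compounds below may be only part of what the source reports. "The series", "measured", "known", "first", "only" and "open" are said of these compounds alone.

Compound 3 `COc1cc2nc(N3CCN(S(=O)(=O)c4ccc(C(=O)O)cc4)CC3)nc(N)c2cc1OC` gives 53000 nM in a functional assay on PC-3 cells (Homo sapiens) for inhibition (a lower number here means a stronger inhibitor, a higher number a weaker inhibitor), the highest number of the three measured; compound 1 `COc1cc2nc(N3CCN(S(=O)(=O)c4ccc(Br)cc4)CC3)nc(N)c2cc1OC` gives 20000 nM and compound 2 `COc1cc2nc(N3CCN(S(=O)(=O)c4ccc(C(C)(C)C)cc4)CC3)nc(N)c2cc1OC` gives 4100 nM. Compound 4 `CCCCc1ccc(-c2ccc(S(=O)(=O)N3CCN(c4nc(N)c5cc(OC)c(OC)cc5n4)CC3)cc2)cc1` is not yet measured. Its change from compound 3 is 4-butylphenyl in place of carboxy on an aromatic carbon. Going by the values given here, two measured steps bear on it, both ending at the carboxy compound: a 13-fold higher number from compound 2 to compound 3 (1.11 log units; beyond the scatter) and a 2.7-fold higher number from compound 1 to compound 3 (0.42 log units; beyond the scatter). Replacing carboxy with 4-butylphenyl undoes the carboxy introduction, and the larger of these two steps is the better guide, so a large drop in the number in this assay is expected. The expected step is a 27-fold lower number from compound 3 to compound 4 (1.42 log units; beyond the scatter). For compound 4 the estimate is 2000 nM, with a range from 500 nM to 8000 nM.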

Compound 4, half-maximal inhibitory concentration: 3400 nM
Beside the measured number, compound 4's estimate is 1.7-fold (0.23 log units) below it; measured number inside the range.
By their numbers in this assay, from the lowest: compounds 4 and 2 (each within the scatter of the next); then compound 1; then compound 3.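

At this aromatic carbon in this assay, 4-butylphenyl brings the number down from that of the carboxy compound (a 16-fold lower number from compound 3 to compound 4 (1.19 log units; beyond the scatter)) and from that of the bromo compound (a 5.9-fold lower number from compound 1 to compound 4 (0.77 log units; beyond the scatter)). Against tert-butyl, however, it gives no separable change (a 1.2-fold lower number from compound 2 to compound 4 (0.08 log units; within the scatter)), so the added six-membered aromatic ring and butyl chain show no gain over tert-butyl here.

As far as these compounds go, whether an amine, a methoxy group or a shorter chain on the added ring would group with compound 2 and compound 4 remains open. Nothing available accounts for these differences.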